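The compounds below may be only part of what the source reports. "The series", "measured", "known", "first", "only" and "open" are said of these compounds alone.

Compound 1 `O=c1[nH]cc(S(=O)(=O)Nc2ccccc2-c2cn(-c3cccc(Cl)c3)nn2)c(=O)[nH]1` and compound 2 `O=c1[nH]cc(S(=O)(=O)Nc2ccccc2-c2cn(-c3ccc(Cl)cc3)nn2)c(=O)[nH]1` share one core and differ by 4-chlorophenyl in place of 3-chlorophenyl on an aromatic nitrogen. In an ADME assay on GES1 cells (Homo sapiens) for cytotoxicity, read by MTT assay, with a stated time of 24 h (a lower number here means that less compound is tolerated, a higher number that more compound is tolerated), compound 1 gives only a limit, > 100000 nM. In this assay compound 2 gives 26700 nM. The step between them is an at least 3.7-fold lower number from compound 1 to compound 2 (0.57 log units; beyond the scatter); its true size is open-ended because the limit of > 100000 nM in this assay, at which 1 of the 3 values shown sits, caps what compound 1 can show. Compound 3 `O=c1[nH]cc(S(=O)(=O)Nc2ccc(-c3cn(-c4cccc(Cl)c4)nn3)cc2)c(=O)[nH]1` carries a different core; the difference between the two cores is not broken down here. In this assay compound 3 gives 7570 nM. Compound 4 `O=c1[nH]cc(S(=O)(=O)Nc2ccc(-c3cn(-c4ccc(Cl)cc4)nn3)cc2)c(=O)[nH]1` differs from compound 3 by 4-chlorophenyl in place of 3-chlorophenyl on an aromatic nitrogen, the same change as from compound 1 to compound 2. From compound 3 to compound 4 a step of a 2.7-fold lower number from compound 3 to compound 4 (0.43 log units; beyond the scatter) is expected, resting on the measured step of an at least 3.7-fold lower number from compound 1 to compound 2 (0.57 log units; beyond the scatter), which is only a lower bound. Compound 4 is therefore estimated at 2800 nM in this assay, with a likely range from 1100 nM to 7500 nM.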

Compound 4, half-maximal cytotoxic concentration: 23300 nM
Compound 4: the middle estimate sits 8.3-fold (0.92 log units) below what was measured; the whole stated range lies below it.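

In this assay the change from 3-chlorophenyl to 4-chlorophenyl gives a 3.1-fold higher number from compound 3 to compound 4 (0.49 log units; beyond the scatter), so on these two cores the step does not carry over, not even in direction: the same change on two cores in this assay, an at least 3.7-fold lower number (0.57 log units; beyond the scatter) from compound 1 to compound 2 and a 3.1-fold higher number (0.49 log units; beyond the scatter) from compound 3 to compound 4, at least 11-fold (1.06 log units) apart, beyond the scatter of two such steps. From the compounds shown here alone, the size of that gap stays open-ended, as compound 1 stands at a limit: the limit of > 100000 nM in this assay, at which 1 of the 4 values shown sits. The pair gives no reason for the reversal and says nothing about how the change would run on any further core.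

Left open is whether the same shift with a methoxy or a fluorine in place of the chlorine on the phenyl ring would follow the chlorine pairs on both cores. Equally open, going by these compounds, is how an amine or a carboxylic acid on that phenyl ring would read in this assay.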